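Amino in place of nitro: compound 3 to compound 4

A few compounds are considered here, and "the series" means these few. Any claim that something is new, unique, unknown or untested is made for them only; others in the source may bear on it.

Among the compounds with values here, in a functional assay on DU-145 cells (Homo sapiens) for cytotoxicity, read by trypan blue exclusion, with a stated time of 96 h (on this read-out lower numbers stand for stronger inhibition and higher numbers for weaker inhibition), compound 3 `COc1cc(OC)c(/C=C/S(=O)(=O)Cc2ccc(Br)c([N+](=O)[O-])c2)c(OC)c1` gives 25000 nM, the highest of the three numbers so far. Compound 4 `COc1cc(OC)c(/C=C/S(=O)(=O)Cc2ccc(Br)c(N)c2)c(OC)c1` is not yet measured. It carries amino in place of nitro on an aromatic carbon, ortho to a bromo group and meta to a large group (amino in place of nitro on an aromatic carbon).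

Within the data shown here, no measured step makes this exchange. Among the measured compounds shown here, the only step, a 3.0-fold higher number from compound 1 to compound 2 (0.48 log units; beyond the scatter), links compound 1 `COc1cc(OC)c(/C=C/S(=O)(=O)Cc2ccc(F)c(N)c2)c(OC)c1` to compound 2 `COc1cc(OC)c(/C=C/S(=O)(=O)Cc2cc(N)ccc2OC)c(OC)c1`, both amino compounds, so it shows only the modest spread among amino compounds. Both stand lower than compound 3, compound 1 at 2500 nM and compound 2 at 7500 nM, but each also differs from compound 3 elsewhere, so this comparison is indirect. With three compounds, none goes against it.

A clear drop beyond the scatter is therefore expected in this assay. The expected step is a 7.1-fold lower number from compound 3 to compound 4 (0.85 log units; beyond the scatter). For compound 4 the estimate is 3500 nM, with an expected range of 1300 nM to 12000 nM.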

Compound 4, half-maximal inhibitory concentration: 750 nM
Beside the measured number, compound 4's estimate is 4.7-fold (0.67 log units) above it, and the stated range ends above it.
By their numbers in this assay, from the lowest: compound 4; then compound 1; then compound 2; then compound 3.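

In this assay, the exchange now has a direct reading on an aromatic carbon ortho to a bromo group: amino in place of nitro gives a 33-fold lower number from compound 3 to compound 4 (1.52 log units; beyond the scatter), a large step. The halogen on the amino compounds also matters, with bromo in place of fluoro giving a 3.3-fold lower number from compound 1 to compound 4 (0.52 log units; beyond the scatter), while 3-amino-4-bromophenyl in place of 5-amino-2-methoxyphenyl gives a 10-fold lower number from compound 2 to compound 4 (1.00 log units; beyond the scatter), so compound 4 stands lowest of the four, with its steps to all three others beyond the scatter. Nothing available here accounts for either drop.

As far as these compounds go, the amino-for-nitro step rests on a single pair, so whether it holds with fluoro in place of bromo remains open. Also open, from the compounds shown here alone, is how a hydroxyl, acetamide or dimethylamino group would read on the same aromatic carbon, and where chloro or iodo would fall relative to bromo.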